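Sulfonylation of the amino nitrogen on the shared core

A few compounds are considered here, and "the series" means these few. Any claim that something is new, unique, unknown or untested is made for them only; others in the source may bear on it.

Compound 1 `Cc1cc2c(c(N)nn2C)c(=O)[nH]1` stands second highest of the three numbers in an assay on isolated protein for inhibition of RAC-beta serine/threonine-protein kinase (Homo sapiens), read by mobility shift assay, tested at 30 uM (a lower number here means less inhibition, a higher number more inhibition at the concentration tested (going by the name of the read-out)), where compound 1 gives 4%. Compound 3 `COC(=O)CCc1c(C)[nH]c(=O)c2c(N)nn(C)c12` gives 3%, and compound 2 `Cn1nc(N)c2c(=O)[nH]c(-c3ccccn3)cc21` gives 10%; the steps of a number 1 percentage points lower from compound 1 to compound 3 (within the scatter) and a number 6 percentage points higher from compound 1 to compound 2 (within the scatter) both lie within the scatter. Compound 4 `Cc1cc2c(c(NS(C)(=O)=O)nn2C)c(=O)[nH]1` differs from compound 1 by methylsulfonyl in place of hydrogen on a nitrogen on an aromatic ring. Among the compounds with values here, neither measured step touches the amino nitrogen: one puts pyridin-2-yl in place of methyl on an aromatic carbon, the other puts 2-(methoxycarbonyl)ethyl in place of hydrogen on an aromatic carbon, so no direct precedent exists for this change. Both measured steps stayed within the scatter, and nothing in the series points to a move beyond it. For compound 4 the estimate is 5%, between -5% and 15%. The step of a number 1 percentage points higher from compound 1 to compound 4 (within the scatter) is expected to stay within the scatter.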

Compound 4, a percentage reported as inhibition, at one concentration (the size of the read-out at that concentration, not a potency): 16%
For compound 4 the middle estimate is 11 percentage points below the measured one; measured number above the stated range.
By their numbers in this assay, from the lowest: compounds 3, 1, 2 and 4 (each within the scatter of the next, the first and the last beyond it).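

Within the data shown here, on the shared core, the amino nitrogen is the first place where a single change moves the number in this assay beyond the scatter: methylsulfonyl in place of hydrogen gives a number 12 percentage points higher from compound 1 to compound 4 (beyond the scatter), a modest step. The two changes on aromatic carbons stayed within the scatter. No measurement available bears on the reason for this step.

Still open, going by these compounds, is whether the step is specific to methylsulfonyl, which an acetyl or phenylsulfonyl group on this nitrogen would test. Also open, on these data alone, is whether methylsulfonyl gives a similar step on compound 2.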